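Methoxyphenyl for fluorophenyl on the indazole sulfonyl position

This account rests on a few compounds, and the source may have more. Where it says the series, first, only, none or still open, it means among the compounds named here.

Compound 1 `Cc1ccc(S(=O)(=O)c2n[nH]c3ccc(N4CCN(C)CC4)cc23)cc1`: an assay on HeLa cells for displacement of a labelled ligand from 5-hydroxytryptamine receptor 6 (Homo sapiens) (a higher number here means a weaker inhibitor, a lower number a stronger inhibitor), 4.9 nM
Compound 2 `O=S(=O)(c1cccc(F)c1)c1n[nH]c2cccc(N3CCNCC3)c12`: 134 nM

Compound 2 has the higher of the two numbers; compound 1 has a number lower by a margin well beyond the scatter. Compound 3 `COc1ccc(S(=O)(=O)c2n[nH]c3cccc(N4CCNCC4)c23)cc1` differs from compound 2 by 4-methoxyphenyl in place of 3-fluorophenyl on a sulfonyl sulfur. Going by the values given here, no measured pair shows this change, so its size cannot be read from the data; compound 1, which carries a substituted phenyl on the same sulfur, gives 4.9 nM, but it differs elsewhere too. A modest step toward a lower number is expected, with wide uncertainty. Compound 3 is estimated at 60 nM, between 15 nM and 250 nM. This estimate means an expected step of a 2.2-fold lower number from compound 2 to compound 3 (0.35 log units; beyond the scatter).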

Compound 3, inhibition constant: 88 nM
Beside the measured number, compound 3's estimate is 1.5-fold (0.17 log units) below it, within the range that was stated.
By their numbers in this assay, from the lowest: compound 1; then compounds 3 and 2 (each within the scatter of the next).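

Set in this assay, 4-methoxyphenyl in place of 3-fluorophenyl on a sulfonyl sulfur gives the first one-place comparison at this position: a 1.5-fold lower number from compound 2 to compound 3 (0.18 log units; within the scatter). This single change therefore leaves compound 2 and compound 3 indistinguishable in this measurement. No supporting measurement offers an explanation for this result.

On these data alone, what an aminophenyl or a carboxylic acid on the phenyl ring would do on this sulfur remains open. Compound 1 differs from compound 2 and compound 3 in more than one place, so it cannot settle this position.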